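The source may hold more compounds than are shown below. What is called first, only, known or untested is meant among the compounds shown, and "the series" means these compounds.

Measured so far:
Compound 1, `C=C[C@@](C)(/C=C/c1ccc(Nc2ccccc2)cc1)CCC=C(C)C`, gives > 36600 nM in an ADME assay on BJ cells (Homo sapiens) for cytotoxicity, with a stated time of 72 h (a higher number here means that more compound is needed for the effect, a lower number that less compound is needed), a limit of the assay.
Compound 2, `C=C[C@@](C)(/C=C/c1ccc(Nc2c(F)cc(F)cc2F)cc1)CCC=C(C)C`, gives > 36600 nM in this assay, a limit of the assay.

For the measured compounds named here, compound 2 therefore stands only at a limit in this assay, and the one further value in the set, that of compound 1, is a limit as well. Going by the values given here, the single measured change, 2,4,6-trifluorophenyl in place of phenyl on a nitrogen on an aromatic ring, gives a step that the two limits leave unreadable from compound 1 to compound 2; it cannot be read because of the limit of > 36600 nM in this assay, at which 2 of the 2 values shown sit.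

Compound 3 is `C=C[C@@](C)(/C=C/c1ccc(Nc2ccc(Cl)c(Cl)c2)cc1)CCC=C(C)C`. Against compound 2 the change is 3,4-dichlorophenyl in place of 2,4,6-trifluorophenyl on a nitrogen on an aromatic ring. Among the compounds with values here, no measured step bears on this change: the only step in hand is unreadable, and it concerns a different group on the same nitrogen. With both values at the limit, no direction can be expected in this assay. The expected step is a step that the limit leaves unreadable from compound 2 to compound 3, with the result most likely reported again as a limit. The estimate for compound 3 in this assay is 50000 nM, with a range of 20000 nM to 200000 nM.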

Compound 3, half-maximal effective concentration: > 36600 nM
Compound 3 was reported as a limit (the forecaster's own chance of this, stated with the estimate: 80%); the middle value does not contradict the limit.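

No step among compound 1, compound 2 and compound 3 can be read in this assay, and all of them stay unreadable because of one shared limit: the limit of > 36600 nM in this assay, at which 3 of the 3 values shown sit.

The compounds shown leave open whether phenyl, 2,4,6-trifluorophenyl or 3,4-dichlorophenyl on the nitrogen makes any difference in this assay and, if so, in which direction.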